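A few compounds are considered here, and "the series" means these few. Any claim that something is new, unique, unknown or untested is made for them only; others in the source may bear on it.

Two analogues of the shared core have numbers in a functional assay on A549 cells (Homo sapiens) for cytotoxicity, read by sulforhodamine B assay, with a stated time of 72 h; on this read-out higher numbers stand for weaker inhibition and lower numbers for stronger inhibition. Compound 1 `O=C1/C(=C/c2coc3ccccc3c2=O)N=C(c2ccc(Cl)cc2)N1c1ccc(S(=O)(=O)Nc2ncccn2)cc1` gives 59000 nM, and compound 2 `O=C1/C(=C/c2coc3ccccc3c2=O)N=C(c2ccccc2)N1c1ccc(S(=O)(=O)Nc2nccs2)cc1` gives 88400 nM. Compound 2 stands at the highest of these two numbers, but the gap to compound 1 lies within the scatter, so the two show no difference. Within the data shown here, compound 3 `O=C1/C(=C/c2coc3ccccc3c2=O)N=C(c2ccc(Cl)cc2)N1c1ccc(S(=O)(=O)Nc2nccs2)cc1` differs from compound 2 by chloro in place of hydrogen on an aromatic carbon; no such step has been measured. No step beyond the scatter is expected here. For compound 3 the estimate is 70000 nM, with a range of 30000 nM to 160000 nM, which means an expected step of a 1.3-fold lower number from compound 2 to compound 3 (0.10 log units; within the scatter) from compound 2 to compound 3.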

Compound 3, half-maximal inhibitory concentration: > 100000 nM
Compound 3: only a limit was reported; the forecaster's own chance of this, stated with the estimate: 15%; at least 1.4-fold (0.15 log units) between middle value and limit.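

In this assay compound 3 gives > 100000 nM, which is a limit and not a number. Chloro in place of hydrogen on the aromatic carbon gives an at least 1.1-fold higher number from compound 2 to compound 3 (0.05 log units; that floor lies within the scatter), and 1,3-thiazol-2-yl in place of pyrimidin-2-yl on the sulfonamide nitrogen gives an at least 1.6-fold higher number from compound 1 to compound 3 (0.22 log units; that floor lies within the scatter), so neither change is shown to shift the read-out. The full size of either step cannot be read: the limit of > 100000 nM in this assay, at which 1 of the 3 values shown sits.

Open, from the compounds shown here alone, is whether an amine or a methoxy group at this position would give a number inside the measurable range of this assay. Also open, going by these compounds, is how chloro acts when pyrimidin-2-yl sits on the sulfonamide nitrogen.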